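This account rests on a few compounds, and the source may have more. Where it says the series, first, only, none or still open, it means among the compounds named here.

Working notes on the series, read in an ADME assay on HEK-293T cells (Homo sapiens) for cytotoxicity, read by MTT assay, with a stated time of 24 h (a higher number here means that more compound is tolerated, a lower number that less compound is tolerated), throughout. Compound 1 (`FC(F)(F)c1ccc(-c2nn(-c3ccccc3)cc2-c2nc3ccccc3[nH]2)cc1`) gives 167000 nM and compound 2 (`Cc1ccc(-c2nn(-c3ccccc3)cc2-c2nc3ccccc3n2S(=O)(=O)c2ccc(C)cc2)cc1`) gives 79300 nM in this read-out. Compound 2 therefore holds the lower of the two values, and its gap to compound 1 lies beyond the usual scatter. These two compounds differ in more than one place, so the gap cannot be tied to a single change.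

Next is compound 3 (`Cc1ccc(-c2nn(-c3ccccc3)cc2-c2nc3ccccc3n2S(=O)(=O)c2ccc(Cl)cc2)cc1`), which carries chloro in place of methyl on an aromatic carbon para to a large group. The same difference reads as (4-methylphenyl)sulfonyl to (4-chlorophenyl)sulfonyl. For the measured compounds named here, no measured pair covers this change, so the data offer no direct precedent for it. In this assay no step beyond the scatter is expected, and no direction is favoured. The expectation is anchored on compound 2 at 79300 nM as the closest measured structure. The expected outcome is a 1.1-fold lower number from compound 2 to compound 3 (0.02 log units; within the scatter) and no larger. For compound 3 the estimated value is 75000 nM with an expected range from 35000 nM to 160000 nM in this read-out.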

Compound 3, half-maximal cytotoxic concentration: 167000 nM
The estimate for compound 3 lay 2.2-fold (0.35 log units) below the measured number; the measured number lies above the stated range.
By their numbers in this assay, from the lowest: compound 2; then compounds 1 and 3 (each within the scatter of the next).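

In this assay, for the compounds shown here, the change from (4-methylphenyl)sulfonyl to (4-chlorophenyl)sulfonyl gives the first comparison that differs in one place: a 2.1-fold higher number from compound 2 to compound 3 (0.32 log units; beyond the scatter). This shows that the position para to a large group is not silent in this read-out, since chloro in place of methyl on this aromatic carbon goes with more compound being tolerated, although the step is modest and rests on a single pair, so it gives a direction for this one change on this one background and no trend. Nothing on hand bears on the origin of this step, and none can be assigned to either group.

From the compounds shown here alone, whether other groups at this same position, such as fluoro, methoxy, an amine or a carboxylic acid, would follow chloro or stay with methyl remains open. Also open, going by these compounds, is whether the step holds on other backgrounds, for example with trifluoromethyl in place of the methyl on the other aromatic ring of compound 2, and what the sulfonyl group itself contributes, as compound 1 and compound 2 differ in more than one place.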